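The compounds below may be only part of what the source reports. "The series", "measured", "known", "first", "only" and "open" are said of these compounds alone.

Compound 1 `O[C@H](Cc1ccccc1)CN1CCN(CCCN(c2ccc(F)cc2)c2ccc(F)cc2)CC1` and compound 2 `CCC(=O)OC(CCN1CCN(CCCN(c2ccc(F)cc2)c2ccc(F)cc2)CC1)c1ccccc1` were both tested in an assay on membranes from striatum for displacement of a labelled ligand from sodium-dependent dopamine transporter (Rattus norvegicus); a lower number here means a stronger inhibitor, a higher number a weaker inhibitor. In this assay compound 1 gives 5.36 nM, the lowest of the two numbers, while compound 2 gives 5.57 nM, which lies within the scatter of compound 1. Compound 3 `O[C@@H](Cc1ccccc1)CN1CCN(CCCN(c2ccc(F)cc2)c2ccc(F)cc2)CC1` has not yet been measured. It differs from compound 1 in this way: the two compounds have the same atoms and bonds and differ only in configuration as drawn: 1 of 1 stereo elements differ; a stereocentre at a saturated chain carbon is drawn R in compound 1 and S in compound 3. Going by the values given here, with no comparable pair on record, compound 3 is expected to sit close to compound 1, with a step of a 1.5-fold higher number from compound 1 to compound 3 (0.17 log units; within the scatter) that may or may not exceed the scatter. Compound 3 is therefore estimated at 8 nM in this assay, with a range from 3 nM to 25 nM.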

Compound 3, inhibition constant: 1.72 nM
Compound 3: middle estimate off by 4.7-fold (0.67 log units), on the high side, outside the stated range (below it).
By their numbers in this assay, from the lowest: compound 3; then compounds 1 and 2 (each within the scatter of the next).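

In this assay, the stereocentre at the saturated chain carbon proves to matter: going from R to S gives a 3.1-fold lower number from compound 1 to compound 3 (0.49 log units; beyond the scatter). This is the first step on record at this position, and the change can be assigned to configuration alone, because of one fact: the fact that compounds 1 and 3 differ only in the configuration as drawn

The compounds shown leave open whether S would remain the better configuration with an amine or a methyl ether in place of the hydroxyl group at this carbon. They also leave open whether it would hold with a longer chain leading to the phenyl ring.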